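The compounds below may be only part of what the source reports. "The series", "measured", "known", "first", "only" and "open" are said of these compounds alone.

Of the compounds shown here, three built on one shared core have been measured in an ADME assay on A549 cells (Homo sapiens) for cytotoxicity, read by resazurin assay, with a stated time of 48 h; on this read-out lower numbers stand for higher toxicity in this test and higher numbers for lower toxicity in this test. Compound 1, with the structure `CCCN(CCC)c1ccc(NC(=O)c2cc(Cl)ccc2O)c(Cl)c1`, gives 10700 nM, the lowest of the three numbers. Compound 2, `CC1(ON(c2ccc(NC(=O)c3cc(Cl)ccc3O)c(Cl)c2)C2(C)CCCC2)CCCC1`, gives 18000 nM, a number that sits within the usual scatter of compound 1. Compound 3, `O=C(Nc1ccc(NCc2cc(C(F)(F)F)cc(C(F)(F)F)c2)cc1Cl)c1cc(Cl)ccc1O`, gives 92800 nM, and that number lies well beyond the scatter above compound 1. So compound 1 stands at the more toxic end of the set as it is known so far, while compound 3 stands at the less toxic end.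

The next compound, compound 4, has the structure `O=C(Nc1ccc(NCc2ccc(O)nc2)cc1Cl)c1cc(Cl)ccc1O`. Its difference from compound 1 is ((6-hydroxypyridin-3-yl)methyl)amino in place of dipropylamino on an aromatic carbon. Among the compounds with values here, no pair of measured compounds differs in exactly this way, so the size of the step has to be guessed from the spread seen so far. Compounds 1 and 2 both carry a nitrogen bound to two alkyl groups and give the lower numbers, while compound 3 carries a nitrogen bound to a single methylene-linked ring and gives the highest number; compound 4 follows the second pattern. A step upward beyond the scatter is therefore expected, of the size a 3.3-fold higher number from compound 1 to compound 4 (0.51 log units; beyond the scatter). The estimate for compound 4 in this assay is 35000 nM, with a range from 12000 nM to 95000 nM.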

Compound 4, half-maximal cytotoxic concentration: 98500 nM
Compound 4: the middle estimate sits 2.8-fold (0.45 log units) below what was measured, and the stated range ends below it.
By their numbers in this assay, from the lowest: compounds 1 and 2 (each within the scatter of the next); then compounds 3 and 4 (each within the scatter of the next).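

Within this assay, this is the first change at a single place in the set, and it shows that the group on this aromatic carbon, meta to a chloro group and para to a large group, can by itself move the number well beyond the scatter: replacing dipropylamino with ((6-hydroxypyridin-3-yl)methyl)amino gives a 9.2-fold higher number from compound 1 to compound 4 (0.96 log units; beyond the scatter). A higher number here stands for lower toxicity in this test, so the rest of the molecule remains the same while the cells tolerate compound 4 better than compound 1. The swap alters several things at once, since a ringless group without hydrogen-bond donors gives way to one with a six-membered aromatic ring, a ring nitrogen, a hydroxyl and hydrogen-bond donors, and no measurement shown here explains the shift.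

The compounds shown leave open which part of the entering group goes with the higher number, the ring, its hydroxyl or the nitrogen-hydrogen link to the core. A simple propylamino group or an unsubstituted benzylamino group at this position would help to separate those parts.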